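The source may report more compounds than this note shows. Statements on the series, on what has been measured and on what is new or still open speak of the compounds shown alone.

Compound 1 `Cn1c(-c2ccc([N+](=O)[O-])cc2)nc2cc(C(F)(F)F)ccc21`, compound 2 `CC(=O)Nc1ccc(-c2nc3cc(C(F)(F)F)ccc3n2C)cc1` and compound 3 `O=[N+]([O-])c1ccc(-c2nc3cc(Cl)c(Cl)cc3[nH]2)cc1` have been measured. In an ADME assay on MT4 cells (Homo sapiens) for cytotoxicity, read by MTT assay, with a stated time of 96 h (a higher number here means that more compound is tolerated, a lower number that less compound is tolerated), compound 1 gives >= 100000 nM, which is a limit of the assay rather than a number. In this assay compound 2 gives 15000 nM. In this assay compound 3 gives 17000 nM, within the usual scatter of the value of compound 2. Compound 4 `CC(=O)Nc1ccc(-c2nc3cc(Cl)c(Cl)cc3[nH]2)cc1` has not been measured yet.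

The change from compound 1 to compound 2 is acetamido in place of nitro on an aromatic carbon, and it made an at least 6.6-fold lower number from compound 1 to compound 2 (0.82 log units; beyond the scatter). The change from compound 3 to compound 4 is the same one: acetamido in place of nitro on an aromatic carbon. The difference between the two cores is not broken down here. The earlier step began at a limit (the limit of >= 100000 nM in this assay, at which 1 of the 3 values shown sits), so only its least size is known. Compound 4 is therefore expected to take a smaller step, a 1.9-fold lower number from compound 3 to compound 4 (0.28 log units; within the scatter), resting on compound 3 at 17000 nM. Compound 4 is estimated at 9000 nM, with a likely range from 3000 nM to 30000 nM.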

Compound 4, half-maximal cytotoxic concentration: > 100000 nM
Compound 4: no number, only a limit; the forecaster's own chance of this, stated with the estimate: 5%; middle value at least 11-fold (1.04 log units) away from the limit.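

Acetamido in place of nitro on an aromatic carbon gave an at least 5.8-fold higher number from compound 3 to compound 4 (0.76 log units; beyond the scatter) in this assay, so the same change did not carry over from one core to the other, and its direction reversed: the same change on two cores in this assay, an at least 6.6-fold lower number (0.82 log units; beyond the scatter) from compound 1 to compound 2 and an at least 5.8-fold higher number (0.76 log units; beyond the scatter) from compound 3 to compound 4, at least 39-fold (1.59 log units) apart, beyond the scatter of two such steps

The value of compound 4, > 100000 nM, is a limit of the assay and not a number: the limit of > 100000 nM in this assay, at which 1 of the 4 values shown sits.

Compound 1 also stands at a limit, so only the least size of each step is known, and the comparison does not show which difference between the two cores goes with the reversal: the limit of >= 100000 nM in this assay, at which 1 of the 4 values shown sits.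

The compounds shown leave open how the change behaves on cores that differ in only one place. They also leave open whether an amine or a carboxylic acid in place of nitro would follow compound 2 or compound 4 in this assay.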